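Aryl Swap on a Shared Core: Cytotoxicity Expectation

The compounds below may be only part of what the source reports. "The series", "measured", "known", "first", "only" and "open" are said of these compounds alone.

Measured compounds:
Compound 1, `N#Cc1c(-c2ccccc2Cl)c(C#N)c(=O)n(/N=C/c2cn(-c3ccccc3)nc2-c2ccccc2)c1N`, in an ADME assay on HeLa cells (Homo sapiens) for cytotoxicity, read by MTT assay (on this read-out lower numbers stand for stronger inhibition and higher numbers for weaker inhibition), gives > 200 ug/mL, a limit of the assay rather than a number.
Compound 2, `N#Cc1c(-c2cccc(Cl)c2)c(C#N)c(=O)n(/N=C/c2cn(-c3ccccc3)nc2-c2ccccc2)c1N`, in this assay gives > 200 ug/mL, again a limit.
Compound 3, `N#Cc1c(-c2ccccc2Br)c(C#N)c(=O)n(/N=C/c2cn(-c3ccccc3)nc2-c2ccccc2)c1N`, in this assay gives > 200 ug/mL, also a limit.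

Compound 3 therefore stands at the limit, the same place as the other two values shown, so no ordering among the three can be read. The steps between them are a step that the two limits leave unreadable from compound 1 to compound 2, a step that the two limits leave unreadable from compound 1 to compound 3 and a step that the two limits leave unreadable from compound 2 to compound 3. What the three values share is the limit of > 200 ug/mL in this assay, at which 3 of the 3 values shown sit.

Compound 4, `N#Cc1c(-c2ccc(C(F)(F)F)cc2)c(C#N)c(=O)n(/N=C/c2cn(-c3ccccc3)nc2-c2ccccc2)c1N`, differs from compound 3 in one place: 4-(trifluoromethyl)phenyl in place of 2-bromophenyl on an aromatic carbon. The measured steps bear on this only loosely, since each swaps one halogen-bearing phenyl for another without leaving the limit, and none of them involves a trifluoromethyl group. Because the limit of > 200 ug/mL in this assay, at which 3 of the 3 values shown sit, holds for every halogen-bearing phenyl measured, compound 4 is expected to give 250 ug/mL, with a range from 120 ug/mL to 600 ug/mL. The step from compound 3 expected for compound 4 is a step that the limit leaves unreadable from compound 3 to compound 4, most likely again reported only as a limit.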

Compound 4, half-maximal inhibitory concentration: > 200 ug/mL
Compound 4 gave a limit, no number; the forecaster's own chance of this, stated with the estimate: 80%; the middle value is on the limit's open side.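

The steps from compound 1, compound 2 and compound 3 to compound 4 cannot be read, because all four results in this assay are limits rather than numbers: the limit of > 200 ug/mL in this assay, at which 4 of the 4 values shown sit.

The compounds shown leave open how these four substituted phenyl groups rank against one another, and whether any group in that place on the shared core would give a measurable value in this assay.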